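Leaving the 4-methylpiperazin-1-yl group behind

A few compounds are considered here, and "the series" means these few. Any claim that something is new, unique, unknown or untested is made for them only; others in the source may bear on it.

In a functional assay on MCF7 cells (Homo sapiens) for antiproliferative activity, read by MTT assay, with a stated time of 48 h (on this read-out higher numbers stand for weaker inhibition and lower numbers for stronger inhibition), compound 2 (`CC(C)=CCC[C@]1(C)/C=C/[C@@H](OC(=O)C=C(C)C)[C@](C)(O)/C=C/C(=O)/C(CN2CCN(C)CC2)=C\C1`) gives 550 nM as the lower of two numbers, while compound 1 (`CC(=O)OC/C1=C/C[C@](C)(CCC=C(C)C)/C=C/[C@@H](OC(=O)C=C(C)C)[C@](C)(O)/C=C/C1=O`) gives 4510 nM on the same read-out. Among the compounds with values here, compound 3 (`CSC(=S)OC/C1=C/C[C@](C)(CCC=C(C)C)/C=C/[C@@H](OC(=O)C=C(C)C)[C@](C)(O)/C=C/C1=O`) has a group of 5 heavy atoms (2 carbon, 1 oxygen, 2 sulfur; no ring) in place of a group of 7 heavy atoms (5 carbon, 2 nitrogen; one six-membered non-aromatic ring with 2 hetero atoms), on a saturated chain carbon bound to a double-bonded ring carbon as its one change from compound 2. Within the data shown here, the only measured step at this place is an 8.2-fold lower number from compound 1 to compound 2 (0.91 log units; beyond the scatter) for 4-methylpiperazin-1-yl in place of acetoxy, a modest step beyond the scatter, and compound 3 no longer carries that group. The expected change in this assay is a 4.5-fold higher number from compound 2 to compound 3 (0.66 log units; beyond the scatter) as a move to a higher number, giving back much of that step. The estimate for compound 3 is 2500 nM with an expected range from 800 nM to 7000 nM around it.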

Compound 3, half-maximal inhibitory concentration: 900 nM
Compound 3: the middle estimate sits 2.8-fold (0.44 log units) above what was measured; the range from low to high includes it.
By their numbers in this assay, from the lowest: compounds 2 and 3 (each within the scatter of the next); then compound 1.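

In this assay the change gives a 1.6-fold higher number from compound 2 to compound 3 (0.21 log units; within the scatter) and so the 4-methylpiperazin-1-yl group is not required at this saturated chain carbon for a number well under that of compound 1. With the oxygen on the saturated carbon kept, replacing the acetyl part with the group that compound 3 carries there gives a 5.0-fold lower number from compound 1 to compound 3 (0.70 log units; beyond the scatter) and thus shows that a ring-free, nitrogen-free group can also reach this range. No evidence on hand accounts for these steps. From the compounds shown here alone, whether a dimethylamino or morpholin-4-yl group, or a free hydroxyl, at this carbon would give a similar number remains open.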